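The compounds below may be only part of what the source reports. "The series", "measured", "known", "first", "only" and "open" are said of these compounds alone.

Compound 1 `Nc1ccn(C2OC(CO)C(Br)C2O)c(=O)n1` gives > 100 ug/mL in a functional assay on P815 cells (Mus musculus) for antiproliferative activity; on this read-out lower numbers stand for stronger inhibition and higher numbers for weaker inhibition. Compound 2 `CS(=O)(=O)O[C@@H]1[C@@H](O)[C@H](n2cc(F)c(N)nc2=O)O[C@@H]1CO` gives 6 ug/mL in this assay. Compound 3 `Nc1nc(=O)n(C2OC(CO)C(Br)C2O)cc1F` gives 5 ug/mL in this assay.

The value of compound 1 is a limit of this assay and not a number (the limit of > 100 ug/mL in this assay, at which 1 of the 3 values shown sits). The numbers of compound 2 and compound 3 lie within the usual scatter of each other. How the core of compound 2 differs from the core of compound 3 is not broken down here.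

Within the data shown here, the one measured step is hydrogen in place of fluoro on an aromatic carbon, and it gave an at least 20-fold higher number from compound 3 to compound 1 (1.30 log units; beyond the scatter).

Compound 4 `CS(=O)(=O)O[C@@H]1[C@@H](O)[C@H](n2ccc(N)nc2=O)O[C@@H]1CO` is not yet measured. It differs from compound 2 by hydrogen in place of fluoro on an aromatic carbon. This is the same kind of change as the measured one, though the surroundings are not identical: in one case the carbon is meta to a group of 9 heavy atoms, in the other meta to a large group.

Because the measured step gave an at least 20-fold higher number from compound 3 to compound 1 (1.30 log units; beyond the scatter), a weakening of similar size is expected here. For compound 4 the expected value is 150 ug/mL, with a likely range from 30 ug/mL to 600 ug/mL. The step is estimated as a 25-fold higher number from compound 2 to compound 4 (1.40 log units; beyond the scatter), and the result may again come out as a limit.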

Compound 4, concentration for 50% inhibition: 22 ug/mL
Estimate against measurement, compound 4: 6.8-fold (0.83 log units) above; the measured number lies below the stated range.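

Putting hydrogen in place of fluoro again weakened the result in this assay with a 3.7-fold higher number from compound 2 to compound 4 (0.56 log units; beyond the scatter) as the new step, so the change points the same way on both cores shown. Its size did not carry over from one core to the other: the same change on two cores in this assay, an at least 20-fold higher number (1.30 log units; beyond the scatter) from compound 3 to compound 1 and a 3.7-fold higher number (0.56 log units; beyond the scatter) from compound 2 to compound 4, at least 5.4-fold (0.73 log units) apart, beyond the scatter of two such steps. Two pairs show only that the direction held here; they do not show why the size differed, and the full size of the first step stays unknown, since compound 1 stands at a limit of the assay and not at a number: the limit of > 100 ug/mL in this assay, at which 1 of the 4 values shown sits.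

The compounds shown carry only fluoro or hydrogen on this aromatic carbon, so it remains open what a chloro or a methyl group would do there. On these data alone, it also remains open whether the change would keep its direction on a third core, for instance one with an amine in the place of the bromine of compound 3.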